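This account rests on a few compounds, and the source may have more. Where it says the series, first, only, none or still open, it means among the compounds named here.

Compound 1 `CC(C)C(c1ncco1)c1ccc(-c2ccc3cccc(F)c3c2)[nH]c1=O` is the reference point of this series. Among the compounds with values here, in an ADME assay on microsomes from liver (Rattus norvegicus) for metabolic stability (on this read-out lower numbers stand for a shorter-lived compound and higher numbers for a longer-lived compound), compound 1 gives 0.0983 h, the lowest of the three numbers so far. Compound 2 `CC(C)C(c1ccc(-c2ccc3cccc(F)c3c2)[nH]c1=O)N1CCCCC1=O` gives 0.102 h in this assay, the change being a 1.0-fold higher number from compound 1 to compound 2 (0.02 log units; within the scatter). Compound 3 `CC(C)C(c1ccc(-c2ccc3cccc(F)c3c2)[nH]c1=O)N1CCN/C1=N\C#N` gives 0.327 h, a step of a 3.3-fold higher number from compound 1 to compound 3 (0.52 log units; beyond the scatter); the further step a 3.2-fold higher number from compound 2 to compound 3 (0.51 log units; beyond the scatter) is of the same size.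

Compound 4 `CC(C)C(CC(N)=O)c1ccc(-c2ccc3cccc(F)c3c2)[nH]c1=O` differs from compound 1 by carbamoylmethyl in place of 1,3-oxazol-2-yl on a saturated chain carbon bound to an aromatic carbon and a saturated chain carbon. The group that enters has no ring, unlike the groups entering in compound 2 and compound 3. Both steps from compound 1 that bear on this exchange of the group on the saturated chain carbon are known: a 1.0-fold higher number from compound 1 to compound 2 (0.02 log units; within the scatter), within the scatter, and a 3.3-fold higher number from compound 1 to compound 3 (0.52 log units; beyond the scatter), modest. The exchange to carbamoylmethyl is therefore expected to give an upward step of at most modest size, a 1.5-fold higher number from compound 1 to compound 4 (0.18 log units; within the scatter), with a result inside the scatter fully possible. Compound 4 is estimated at 0.15 h in this assay, with a range from 0.07 h to 0.35 h.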

Compound 4, half-life: < 0.0667 h
Compound 4 ended at the assay's limit; the forecaster's own chance of this, stated with the estimate: 5%; middle value at least 2.2-fold (0.35 log units) away from the limit.
By their numbers in this assay, from the lowest: compounds 1 and 2 (each within the scatter of the next); then compound 3. At a limit, below all of these: compound 4.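

In this assay compound 4 stands at a limit of the read-out, not at a number: the limit of < 0.0667 h in this assay, at which 1 of the 4 values shown sits. Within the data shown here, with carbamoylmethyl, the only entering group here with no ring, the exchange on this saturated chain carbon is the first to show a step downward, and the gap to the highest compound is clear: an at least 4.9-fold lower number from compound 3 to compound 4 (0.69 log units; beyond the scatter). The other two steps, an at least 1.4-fold lower number from compound 1 to compound 4 (0.16 log units; that floor lies within the scatter) and an at least 1.5-fold lower number from compound 2 to compound 4 (0.18 log units; that floor lies within the scatter), have floors within the scatter, so neither separates the compounds beyond the scatter on its own.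

Going by these compounds, how far the true number of compound 4 lies past the limit stays open. Also open, on these data alone, is whether a carboxylic acid, an amine or a longer chain ending in the carbamoyl group would stay at this limit or come nearer to compound 3.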